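The source may report more compounds than this note shows. Statements on the series, on what has been measured and on what is new or still open speak of the compounds shown alone.

So far two compounds with a shared core have been tested. In a functional assay (strain AB) with Danio rerio as the target, read by microscopy, with a stated time of 1 h (on this read-out lower numbers stand for an effect already at smaller amounts and higher numbers for an effect only at larger amounts of compound), compound 1 (`CC(C)(C)OC(=O)CCC[N+]1(C)CCc2c(sc(NC(=O)Nc3ccc(Cl)cc3)c2C(N)=O)C1`) gives 250 nM as its half-maximal effective concentration. Compound 2 (`CC(C)(C)OC(=O)N1CCc2c(sc(NC(=O)Nc3ccc(Cl)cc3)c2C(N)=O)C1`) has no number there, and its entry of > 25000 nM is a limit of the assay. On these data alone, compound 2 therefore sits at that limit, and its true position remains unknown.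

Compound 3 (`CC(C)N1CCc2c(sc(NC(=O)Nc3ccc(Cl)cc3)c2C(N)=O)C1`) differs from compound 2 in one place, with isopropyl in place of tert-butoxycarbonyl on an amine nitrogen in a ring. Going by the values given here, no measured pair isolates this change, so its size can only be judged indirectly. Compound 1 also has no tert-butoxycarbonyl on that nitrogen and gives 250 nM in this assay as the sole basis for expecting a move toward smaller amounts. The expected change, estimated as an at least 16-fold lower number from compound 2 to compound 3 (1.22 log units; beyond the scatter) in this assay for now, lies beyond the scatter, although a second result at the limit remains possible. For compound 3 the expected value is about 1500 nM on current evidence, with an estimated range from 200 nM to 12000 nM around it.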

Compound 3, half-maximal effective concentration: 1490 nM
Beside the measured number, compound 3's estimate is 1.0-fold (0.00 log units) above it; the measured number falls inside the stated range.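

In this assay, putting isopropyl in place of tert-butoxycarbonyl on an amine nitrogen in a ring gives an at least 16-fold lower number from compound 2 to compound 3 (1.22 log units; beyond the scatter). Going by these compounds alone, this is the first pair that isolates a change at this nitrogen, and it shows that exchanging this one group on the shared core is enough to bring a compound from a limit of the assay to a measured value, with no net charge on either group. The true size of the step remains unknown, because its starting point is a limit and not a number: the limit of > 25000 nM in this assay, at which 1 of the 3 values shown sits.

The compounds shown leave open which difference between the two groups matters, since the exchange removes the carbonyl and the oxygen atoms and also replaces the larger group with a smaller one; an acetyl group or a plain ethyl group on the same nitrogen would help to separate these. They also leave open how a free secondary amine or a carboxylic acid on a longer chain at this nitrogen would read out in this assay.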